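Bromo in place of chloro on compound 1

The source may report more compounds than this note shows. Statements on the series, on what has been measured and on what is new or still open speak of the compounds shown alone.

Measured in a functional assay on NCI-H292 cells (Homo sapiens) for cytotoxicity, read by MTT assay, with a stated time of 72 h, tested at 1.25 ug/mL; on this read-out higher numbers stand for more inhibition of growth at the one concentration tested and lower numbers for less inhibition of growth:
- compound 1 `O=C1NC(=S)/C(=C/c2ccc(Cl)cc2)S1`: 10%
- compound 2 `O=C1NC(=S)/C(=C/c2cc(Cl)cc(Cl)c2Cl)S1`: 14.2%
- compound 3 `O=C1NC(=S)/C(=C/c2ccccc2Br)S1`: 13.3%

These three compounds share a core and differ in the halogen groups on their aromatic ring. Compound 1 carries a chloro group and gives 10% in this assay. That number lies within the usual scatter of the other two, so the three readings cannot be put in any order.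

The next compound to be tested is compound 4 `O=C1NC(=S)/C(=C/c2ccc(Br)cc2)S1`. It keeps the core of compound 1 but has bromo in place of chloro on an aromatic carbon.

For the measured compounds named here, no two tested compounds differ in only one place, so no measured step shows directly what this exchange does. The closest guide is compound 3, which also bears a bromo group and gives 13.3%, within the scatter of compound 1 at 10%. On that basis, no step beyond the scatter is expected in this assay.

The expected change is a number 2 percentage points higher from compound 1 to compound 4 (within the scatter), which stays inside the scatter. For compound 4 the estimated value is 12%, with an expected range of 3% to 24%.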

Compound 4, percent growth inhibition at one concentration: 1.1%
The estimate for compound 4 lay 10.9 percentage points above the measured number, and the stated range ends above it.
By their numbers in this assay, from the lowest: compounds 4, 1, 3 and 2 (each within the scatter of the next, the first and the last beyond it).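

In this assay, bromo in place of chloro on an aromatic carbon gives a number 8.9 percentage points lower from compound 1 to compound 4 (within the scatter). For the compounds shown here, this is the first direct reading of a single exchange, since the earlier compounds all differed in more than one place. Going by these compounds alone, it shows that at this position, para to a group of 8 heavy atoms, the exchange of one halogen for the other produces no step that can be told apart from the usual scatter, so the apparent drop should not be read as a real loss of growth inhibition. No measurement offers an explanation for the size of this step.

The compounds shown carry only halogen groups on the aromatic ring, so they leave open whether a different kind of group at this same position, such as an amine, a carboxylic acid or a methoxy group, would give a step beyond the scatter. They also leave open whether the same exchange of bromo for chloro would stay within the scatter at another place on the ring, or at a different concentration.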